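A few compounds are considered here, and "the series" means these few. Any claim that something is new, unique, unknown or untested is made for them only; others in the source may bear on it.

Working notes on the series. Compound 1 `NC(=O)c1c(NC(=O)c2ccccc2Cl)sc2c1CCNC2` is the parent of the shared core, with a free hydrogen on the amine nitrogen in the ring. Among the compounds with values here, in a functional assay on HeLa cells (Homo sapiens) for antiproliferative activity, with a stated time of 24 h (on this read-out higher numbers stand for weaker inhibition and lower numbers for stronger inhibition), compound 1 gives 45000 nM, which is the only numerical value in the set so far. Compound 2 `NC(=O)c1c(NC(=O)c2ccc(C(F)(F)F)cc2)sc2c1CCN(Cc1c(Cl)cccc1Cl)C2` carries a different aryl amide and a substituent on that same nitrogen, and in this assay compound 2 reaches only a limit, > 50000 nM. That is the limit at which (the limit of > 50000 nM in this assay, at which 1 of the 2 values shown sits). Within the data shown here, compound 1 therefore stands alone as the sole measured number, and on this read-out it is a weak inhibitor. Compound 3 `NC(=O)c1c(NC(=O)c2ccccc2Cl)sc2c1CCN(C(=O)Nc1ccccc1Cl)C2` keeps everything of compound 1 except at the amine nitrogen in the ring: (2-chlorophenyl)carbamoyl in place of hydrogen on an amine nitrogen in a ring. Among the measured compounds shown here, no pair of measured compounds differs in one place, so no step size can be read from the data. Compound 1 gives 45000 nM. The value of compound 2 is a limit of the assay, not a number. On that basis compound 3 is expected to stay weak, and the step of a 1.3-fold lower number from compound 1 to compound 3 (0.11 log units; within the scatter) is expected to be no larger than the usual scatter. The value expected for compound 3 in this assay is 35000 nM, with a range from 8000 nM to 150000 nM.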

Compound 3, half-maximal inhibitory concentration: 45400 nM
Estimate against measurement, compound 3: 1.3-fold (0.11 log units) below, within the range that was stated.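

The amine nitrogen in the ring now has its first readable step: (2-chlorophenyl)carbamoyl in place of hydrogen gives a 1.0-fold higher number from compound 1 to compound 3 (0.00 log units; within the scatter) in this assay. This nitrogen therefore carries a substituent of 10 heavy atoms, with its own six-membered aromatic ring, one hydrogen-bond donor and one hydrogen-bond acceptor, and the read-out stays within the scatter and in the weak range of the parent. Compound 2 holds a limit of the assay and not a number, and its steps cannot be read: the limit of > 50000 nM in this assay, at which 1 of the 3 values shown sits.

Within the data shown here, the single step covers one substituent on this nitrogen, so it remains open whether a small acetyl group, a plain methyl group, or a phenyl ring carrying a carboxylic acid in place of the chlorine would read the same in this assay. Among these compounds, the aryl amide also stays unresolved, since no pair of compounds with numerical values differs there alone, and a basic amine on that aryl ring would be a separate question.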